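Series notes: the step from compound 2 to compound 4

The source may hold more compounds than are shown below. What is called first, only, known or untested is meant among the compounds shown, and "the series" means these compounds.

All numbers come from an assay on HEK293 cells for inhibition of nuclear factor NF-kappa-B complex (Homo sapiens), read by a luciferase reporter, with stated times of 1 h and 3 h; on this read-out higher numbers stand for weaker inhibition and lower numbers for stronger inhibition.
Compound 1 `CC(C)(C)CNC(=O)C[C@H](NC(=O)CN1CCCCC1)C(=O)N[C@@H](CCc1ccccc1)C(=O)NCc1ccccc1`: compound 1 gives 62 nM.
Compound 2 `CC(C)(C)CNC(=O)C[C@H](NC(=O)CCc1ccccc1)C(=O)N[C@@H](CCc1ccccc1)C(=O)NCc1ccccc1`: compound 2 gives 12 nM.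
Compound 3 `Cc1cc(C(=O)N[C@@H](CC(=O)NCC(C)(C)C)C(=O)N[C@@H](CCc2ccccc2)C(=O)NCc2ccccc2)no1`: compound 3 gives 9 nM.

Compound 2 stands second highest of the three numbers, with compound 3 close at a 1.3-fold lower number from compound 2 to compound 3 (0.12 log units; within the scatter) and compound 1 well apart at a 5.2-fold lower number from compound 1 to compound 2 (0.71 log units; beyond the scatter). Compound 4 `CC(C)(C)CNC(=O)C[C@H](NC(=O)CCc1ccccc1)C(=O)N[C@@H](CCc1ccccc1)C(=O)NCC1CC1` is not yet measured; it differs from compound 2 in cyclopropyl in place of phenyl on a saturated chain carbon bound to an amide-type nitrogen. The measured steps all sit at the other end of the shared core: a 5.2-fold lower number from compound 1 to compound 2 (0.71 log units; beyond the scatter) and a 6.9-fold lower number from compound 1 to compound 3 (0.84 log units; beyond the scatter) exchange the acyl cap and give modest moves, while a 1.3-fold lower number from compound 2 to compound 3 (0.12 log units; within the scatter) stays within the scatter. None of them touches the benzylcarbamoyl end, so nothing measured bears directly on this change, and the series gives no guide to its size. The expectation for compound 4 in this assay is therefore a small step at most, leaning toward a higher number, estimated as a 1.7-fold higher number from compound 2 to compound 4 (0.22 log units; within the scatter). Compound 4 is expected near 20 nM, within 6 nM to 70 nM.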

Compound 4, half-maximal inhibitory concentration: 38 nM
Compound 4: middle estimate off by 1.9-fold (0.28 log units), on the low side; the range from low to high includes it.
By their numbers in this assay, from the lowest: compounds 3 and 2 (each within the scatter of the next); then compounds 4 and 1 (each within the scatter of the next).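

In this assay, the benzylcarbamoyl end of the shared core proves responsive: cyclopropyl in place of phenyl on a saturated chain carbon bound to an amide-type nitrogen gives a 3.2-fold higher number from compound 2 to compound 4 (0.50 log units; beyond the scatter), a modest step and the first measured at this end. The six-membered aromatic ring is not required for activity here, as compound 4 still reads 38 nM with the three-membered ring in its place. No measurement at hand explains the step.

With only phenyl and cyclopropyl shown at this place, the compounds do not separate ring size from aromatic character, and a cyclohexyl or a 4-pyridyl group would bear on that question. Going by these compounds, whether the step carries over to the 5-methyl-1,2-oxazol-3-yl cap of compound 3 also remains open.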